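Chloro for methyl at the chain end: compound 4

The source may hold more compounds than are shown below. What is called first, only, known or untested is meant among the compounds shown, and "the series" means these compounds.

Compound 1 `CCCCc1cn(C[C@H](O)[C@H]2OC(=O)C(OCc3ccccc3)=C2OCc2ccccc2)nn1`: in a functional assay on CFPAC-1 cells (Homo sapiens) for antiproliferative activity, read by MTT assay, with a stated time of 72 h (a lower number here means a stronger inhibitor, a higher number a weaker inhibitor), compound 1 gives 73200 nM.
Compound 2 `COc1ccc(-c2cn(C/C=C3\OC(=O)C(OCc4ccccc4)=C3OCc3ccccc3)nn2)cc1`: in this assay compound 2 gives > 100000 nM, a limit of the assay.
Compound 3 `COc1ccccc1-c1cn(C/C=C2\OC(=O)C(OCc3ccccc3)=C2OCc2ccccc2)nn1`: in this assay compound 3 gives > 100000 nM, a limit of the assay.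

Among the compounds with values here, compound 1 carries the only number in this assay; the other two values are limits. Within the data shown here, the single step with measured ends, a step that the two limits leave unreadable from compound 2 to compound 3, swaps 2-methoxyphenyl for 4-methoxyphenyl and stays unreadable because of the limit of > 100000 nM in this assay, at which 2 of the 3 values shown sit. Compound 4 `O=C1O[C@H]([C@@H](O)Cn2cc(CCCCl)nn2)C(OCc2ccccc2)=C1OCc1ccccc1` differs from compound 1 by chloro in place of methyl on a saturated chain carbon, three bonds along the chain from an aromatic carbon. No measured step touches a butyl chain or a chloro, so nothing among these compounds speaks for or against a shift, and the expected step of a 1.0-fold lower number from compound 1 to compound 4 (0.02 log units; within the scatter) is one within the usual scatter. In this assay compound 4 is therefore estimated at 70000 nM, between 30000 nM and 150000 nM.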

Compound 4, half-maximal inhibitory concentration: 58800 nM
Estimate against measurement, compound 4: 1.2-fold (0.08 log units) above; the range from low to high includes it.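

In this assay, the butyl chain accepts this change at its end: the result is a 1.2-fold lower number from compound 1 to compound 4 (0.10 log units; within the scatter), so chloro in place of methyl on a saturated chain carbon, three bonds along the chain from an aromatic carbon, gives no shift that can be told from the scatter. Within the data shown here, this is the only readable step, and the step between compound 2 and compound 3 cannot be read.

From the compounds shown here alone, whether an amine, a carboxylic acid or a longer chain at this chain end would move the number beyond the scatter remains open. Nothing measured among these compounds bears on the cause of this step.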